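The source may hold more compounds than are shown below. What is called first, only, known or untested is meant among the compounds shown, and "the series" means these compounds.

Compound 1 `O=C(CNC(=O)c1nn(-c2ccccc2)c(=O)c2ccccc12)Nc1nc2ccc(Cl)cc2s1` and compound 2 `Cc1ccc2nc(NC(=O)CNC(=O)c3nn(-c4ccc(F)cc4)c(=O)c4ccccc34)sc2c1` share one core and were both tested in an assay on L cells for inhibition of Protein-serine O-palmitoleoyltransferase porcupine (Mus musculus), read by reporter gene assay, with a stated time of 24 h; on this read-out higher numbers stand for an effect only at larger amounts of compound and lower numbers for an effect already at smaller amounts. In this assay compound 1 gives 30 nM, while compound 2 gives 100 nM, the higher of the two numbers, and that gap lies beyond the usual scatter. Compound 3 `O=C(CNC(=O)c1nn(-c2ccc(F)cc2)c(=O)c2ccccc12)Nc1nc2ccc(Cl)cc2s1` keeps the fluorophenyl of compound 2 but carries chloro in place of methyl on an aromatic carbon, the same group found in compound 1. Going by the values given here, no measured pair isolates this change, so only a moderate drop is expected, an estimated step of a 2.2-fold lower number from compound 2 to compound 3 (0.35 log units; beyond the scatter). Compound 3 is therefore estimated at 45 nM, within 20 nM to 120 nM.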

Compound 3, half-maximal effective concentration: 25 nM
Compound 3: the middle estimate sits 1.8-fold (0.26 log units) above what was measured, and the stated range covers the measured number.
By their numbers in this assay, from the lowest: compounds 3 and 1 (each within the scatter of the next); then compound 2.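

With the fluorophenyl held fixed, chloro in place of methyl on an aromatic carbon gives in this assay a 4.0-fold lower number from compound 2 to compound 3 (0.60 log units; beyond the scatter) and so isolates this position in a single measured pair. At the same place, with chloro kept, fluoro in place of hydrogen on the phenyl gives a 1.2-fold lower number from compound 1 to compound 3 (0.08 log units; within the scatter) and leaves the number essentially unchanged. No measurement here explains why either step has its size. As far as these compounds go, only chloro and methyl are compared at this position on the six-membered ring, so how an amine, a methoxy group or a carboxylic acid would read there remains open.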